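The source may hold more compounds than are shown below. What is called first, only, known or untested is meant among the compounds shown, and "the series" means these compounds.

Compound 1 (`COc1ccc(/C=C/C(=O)Nc2cc(-c3ccc(Br)cc3)[nH]n2)cc1`) reads 770 nM in a functional assay on B16-F10 cells (Mus musculus) for antiproliferative activity, read by MTT assay, with a stated time of 48 h (on this read-out higher numbers stand for weaker inhibition and lower numbers for stronger inhibition), and compound 2 (`O=C(/C=C/c1ccc(Br)cc1)Nc1cc(-c2ccc(Br)cc2)[nH]n1`) reads 1280 nM in the same test. Compound 3 (`O=C(/C=C\c1ccc(C(F)(F)F)cc1)Nc1cc(-c2ccccc2)[nH]n1`) reads 640 nM and so stands within the scatter of both, which leaves the three values without a meaningful order.

The next step goes from compound 3 to compound 4 (`COc1ccc(/C=C\C(=O)Nc2cc(-c3ccccc3)[nH]n2)cc1`). It puts methoxy in place of trifluoromethyl on an aromatic carbon and leaves the rest of the structure unchanged.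

For the measured compounds named here, no measured pair exchanges these two groups. The nearest evidence is the step with bromo in place of methoxy on an aromatic carbon, which gave a 1.7-fold higher number from compound 1 to compound 2 (0.22 log units; within the scatter) and so stayed within the scatter. That step is only a loose guide, since bromo is not trifluoromethyl and compounds 1 and 2 differ from compounds 3 and 4 elsewhere in their structures.

No change beyond the scatter is therefore expected, and the estimate of a 1.1-fold lower number from compound 3 to compound 4 (0.03 log units; within the scatter) carries no firm direction. In this assay compound 4 is expected at 600 nM with an estimated range of 250 nM to 1400 nM for now.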

Compound 4, half-maximal inhibitory concentration: 950 nM
The estimate for compound 4 lay 1.6-fold (0.20 log units) below the measured number; the range from low to high includes it.
By their numbers in this assay, from the lowest: compounds 3, 1, 4 and 2 (each within the scatter of the next).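

In this assay, the exchange at this position can now be read directly: a 1.5-fold higher number from compound 3 to compound 4 (0.17 log units; within the scatter), with methoxy in place of trifluoromethyl on an aromatic carbon, para to a large group. For the compounds shown here, until now, the only guide to this exchange was a step involving bromo and methoxy, a 1.7-fold higher number from compound 1 to compound 2 (0.22 log units; within the scatter), so both exchanges read at this position now stay within the scatter, and neither gives a direction that can be relied on. No available measurement offers an explanation for the size of the new step.

Whether an amine or a carboxylic acid on this aromatic carbon would move the number beyond the scatter remains open, since the compounds shown carry only methoxy, bromo and trifluoromethyl there. Compounds 1 and 2 also differ from compounds 3 and 4 elsewhere in their structures, so it is unresolved whether an exchange at this position would give a similar step in both settings.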